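Working notes: bromo to chloro exchange in the series

This account rests on a few compounds, and the source may have more. Where it says the series, first, only, none or still open, it means among the compounds named here.

Measured so far:
compound 1 `O=C(CCCCC1CCSS1)NCc1cn(CCCCOc2ccc3ccc(=O)oc3c2)nn1`: 45.9%
compound 2 `COc1ccc(-c2cc3ccc(OCCCCn4cc(CNC(=O)CCCCC5CCSS5)nn4)cc3oc2=O)cc1`: 36.8%
compound 3 `O=C(CCCCC1CCSS1)NCc1cn(CCCCOc2ccc3cc(-c4ccc(Br)cc4)c(=O)oc3c2)nn1`: 37.4%

In a functional assay on PC-12 cells (Rattus norvegicus) for cytotoxicity, read by MTT assay, with stated times of 3 h and 2 h, tested at 1 uM (on this read-out higher numbers stand for a stronger effect at the one concentration tested and lower numbers for a weaker effect), compound 3 gives 37.4%, the second highest of the three numbers. Its nearest neighbour is compound 2, and that step reads a number 0.6 percentage points higher from compound 2 to compound 3 (within the scatter), which is within the scatter. The furthest is compound 1, with a number 8.5 percentage points lower from compound 1 to compound 3 (within the scatter), again within the scatter, as is a number 9.1 percentage points lower from compound 1 to compound 2 (within the scatter). None of the three values can therefore be ordered against the others.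

Compound 4 `O=C(CCCCC1CCSS1)NCc1cn(CCCCOc2ccc3cc(-c4ccc(Cl)cc4)c(=O)oc3c2)nn1` is not yet measured. It differs from compound 3 in one place: chloro in place of bromo on an aromatic carbon. For the measured compounds named here, the one measured step that bears on this position is the change from methoxy to bromo on the same aromatic carbon, a number 0.6 percentage points higher from compound 2 to compound 3 (within the scatter), and it stayed within the scatter. The two steps that put a substituted phenyl onto the core, a number 9.1 percentage points lower from compound 1 to compound 2 (within the scatter) and a number 8.5 percentage points lower from compound 1 to compound 3 (within the scatter), were also within the scatter. A further exchange of one halogen for another at that carbon is therefore expected to leave this assay unchanged beyond the scatter, with an expected step of a number 0.4 percentage points lower from compound 3 to compound 4 (within the scatter). Compound 4 is estimated at 37%, with a range from 27% to 47%.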

Compound 4, a percentage reported as activity, at one concentration (the size of the read-out at that concentration, not a potency): 46.2%
Compound 4: the middle estimate sits 9.2 percentage points below what was measured; measured number inside the range.
By their numbers in this assay, from the lowest: compounds 2, 3, 1 and 4 (each within the scatter of the next).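

In this assay, the exchange of bromo for chloro on the 4-substituted phenyl gives a number 8.8 percentage points higher from compound 3 to compound 4 (within the scatter), so a change of one halogen atom at this carbon produces a step of about the same size as those seen on adding the whole substituted phenyl, yet it still does not separate the two compounds. The other two new steps, a number 9.4 percentage points higher from compound 2 to compound 4 (within the scatter) and a number 0.3 percentage points higher from compound 1 to compound 4 (within the scatter), also stay within the scatter, so hydrogen at the core carbon and the 4-methoxyphenyl, 4-bromophenyl and 4-chlorophenyl groups there cannot be told apart on this read-out, and the four compounds give no order and no trend among these groups. No measurement at hand offers an explanation for the size of the halogen step.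

From the compounds shown here alone, what remains open is whether any group at this position can move the read-out beyond the scatter, for example an amine or a carboxylic acid in place of the halogen on the phenyl, or a longer chain in place of the 4-substituted phenyl itself. With a single tested concentration, the compounds shown also leave open how the four would compare across a range of concentrations.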